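A few compounds are considered here, and "the series" means these few. Any claim that something is new, unique, unknown or untested is made for them only; others in the source may bear on it.

Measured so far in a physicochemical assay for lipophilicity, at pH 7.4; on this read-out lower numbers stand for lower lipophilicity and higher numbers for higher lipophilicity:
- compound 1 `CC(C)CN(c1ccc(F)cc1F)S(=O)(=O)c1ccc2c(c1)C(=O)CC(C1CCOCC1)O2`: 3.62
- compound 2 `CCc1ccc(N(CC(C)C)S(=O)(=O)c2ccc3c(c2)C(=O)CC(C2(C)CCOCC2)O3)cc1`: 4.71
- compound 3 `CCc1ccc(N(C2COC2)S(=O)(=O)c2ccc3c(c2)C(=O)CC(C2CCOCC2)O3)cc1`: 2.72

The three measured compounds spread widely on this scale. Compound 2, at 4.71, stands highest of the three. Both compound 1, at 3.62, and compound 3, at 2.72, lie below it by more than the usual scatter of repeated measurements.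

The account now turns to compound 4 `CCc1ccc(N(CC(C)C)S(=O)(=O)c2ccc3c(c2)C(=O)CC(C2CCN(S(C)(=O)=O)CC2)O3)cc1`, which has not yet been measured. It keeps everything in compound 2 except one group on a saturated ring carbon, next to the ring oxygen, where 1-(methylsulfonyl)piperidin-4-yl takes the place of 4-methyloxan-4-yl: 1-(methylsulfonyl)piperidin-4-yl in place of 4-methyloxan-4-yl on a saturated ring carbon.

For the measured compounds named here, no two measured compounds differ in only one place, so the data contain no measured step for this or any other single change. Compound 1 and compound 3 each differ from compound 2 in more than one place, and their gaps cannot be read as a guide to its size. The expectation in this assay therefore rests on the structural change alone, and it points downward by a moderate amount. The expected change is a number 0.51 log units lower from compound 2 to compound 4 (beyond the scatter). For compound 4 the estimated value is 4.2, with an expected range from 3.6 to 4.7.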

Compound 4, distribution coefficient: 3.31
Beside the measured number, compound 4's estimate is 0.89 log units above it; measured number below the stated range.
By their numbers in this assay, from the lowest: compound 3; then compound 4; then compound 1; then compound 2.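

For the compounds shown here, this is the first single-place step, and it shows that the group on this saturated ring carbon, next to the ring oxygen, strongly affects the read-out in this assay: putting 1-(methylsulfonyl)piperidin-4-yl in place of 4-methyloxan-4-yl gives a number 1.40 log units lower from compound 2 to compound 4 (beyond the scatter). The number fell even though the entering group has more heavy atoms, and 2 hydrogen-bond acceptors against 1, so a larger group at this place did not go with a higher number in this pair. No measurement shown gives a reason for the size of this step.

The change bundles several differences, as the methyl on the ring carbon goes, the ring oxygen gives way to a ring nitrogen and a methylsulfonyl group is added, and the compounds shown do not separate their shares of the step. From the compounds shown here alone, whether a piperidin-4-yl carrying a free amine or a 1-acetylpiperidin-4-yl at this place would lie nearer compound 2 or compound 4 remains open, as does whether the step keeps its size when other parts of the molecule differ.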